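From 3-methylphenyl to 3-ethynylphenyl

A few compounds are considered here, and "the series" means these few. Any claim that something is new, unique, unknown or untested is made for them only; others in the source may bear on it.

Values in a functional assay on HOS-TE85 cells (Homo sapiens) for inhibition, read by CCK-8 assay, with a stated time of 72 h; a lower number here means a stronger inhibitor, a higher number a weaker inhibitor:
Compound 1 `COc1ccccc1N1C(=O)CSC1c1cc(C(=O)NCCCCc2ccccc2)cc(C2CC2)c1`: 23.5 nM
Compound 2 `O=C(NCCCCc1ccccc1)c1cc(F)cc(C2SCC(=O)N2c2ccccn2)c1`: 14.2 nM
Compound 3 `Cc1cccc(N2C(=O)CSC2c2cccc(C(=O)NCCCCc3ccccc3)c2)c1`: 93.2 nM

Compound 3 stands highest of the three at 93.2 nM. Compound 1 gives 23.5 nM and compound 2 gives 14.2 nM. The gaps from each of these two to compound 3 lie beyond the scatter. Compound 4 `C#Cc1cccc(N2C(=O)CSC2c2cccc(C(=O)NCCCCc3ccccc3)c2)c1` differs from compound 3 in one place: ethynyl in place of methyl on an aromatic carbon, meta to a large group (ethynyl in place of methyl on an aromatic carbon). Going by the values given here, no measured pair isolates a single change, so the data offer no direct guide to this swap. In this assay only a small shift towards a lower number is expected, within the scatter. The expected change is a 1.4-fold lower number from compound 3 to compound 4 (0.16 log units; within the scatter). Compound 4 is estimated at 65 nM, with an expected range from 22 nM to 190 nM.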

Compound 4, half-maximal inhibitory concentration: 149 nM
Estimate against measurement, compound 4: 2.3-fold (0.36 log units) below, and the stated range covers the measured number.
By their numbers in this assay, from the lowest: compounds 2 and 1 (each within the scatter of the next); then compounds 3 and 4 (each within the scatter of the next).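

In this assay, ethynyl in place of methyl on the aromatic carbon, meta to a large group, gives a 1.6-fold higher number from compound 3 to compound 4 (0.20 log units; within the scatter). Going by these compounds alone, this is the first comparison here that isolates a single change, and it shows that the second carbon and the triple bond leave the number within the scatter at this position. Nothing measured here explains this result.

Still open, as far as these compounds go, is whether a nitrile, a trifluoromethyl or an amine in this place would move the number beyond the scatter.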